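From compound 1 to compound 3: one side-chain change

The source may report more compounds than this note shows. Statements on the series, on what has been measured and on what is new or still open speak of the compounds shown alone.

Compound 1 (`O=C1c2c[n+]([O-])c3ccccc3c2C(=O)c2c1c1ccccc1n2CCCCN1CCNCC1`): 1380 nM
Compound 2 (`CC1(C)O[C@@H](CO)[C@H](Cn2cc(Cn3c4c(c5ccccc53)C(=O)c3c[n+]([O-])c5ccccc5c3C4=O)nn2)O1`): 500 nM

In a toxicity assay on L02 cells (Homo sapiens) for cytotoxicity, read by MTT assay, with a stated time of 72 h (a lower number here means a stronger inhibitor, a higher number a weaker inhibitor), compound 1 gives the higher of the two numbers (1380 nM), which makes it the weaker inhibitor of the pair. Compound 2 lies lower (500 nM), and this gap is larger than the usual scatter of repeated measurements.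

Compound 3 (`CN1CCN(CCCCCCn2c3c(c4ccccc42)C(=O)c2c[n+]([O-])c4ccccc4c2C3=O)CC1`) has not yet been measured. It differs from compound 1 only in its side chain, with 2-(4-methylpiperazin-1-yl)ethyl in place of piperazin-1-yl on a saturated chain carbon, four bonds along the chain from an aromatic nitrogen.

Within the data shown here, no measured pair shows this exact change, so any expectation remains loose. The only other reference point is compound 2 (500 nM), which lies below compound 1 and leaves some room for a lower number. The expected step (a 1.5-fold lower number from compound 1 to compound 3 (0.19 log units; within the scatter)) points slightly downward and stays within the scatter. The estimate for compound 3 in this assay is 900 nM (expected range 300 nM to 2700 nM).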

Compound 3, half-maximal inhibitory concentration: 3800 nM
Compound 3: middle estimate off by 4.2-fold (0.63 log units), on the low side; the measured number lies above the stated range.
By their numbers in this assay, from the lowest: compound 2; then compound 1; then compound 3.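

In this assay the side chain at this position turns out to matter: 2-(4-methylpiperazin-1-yl)ethyl in place of piperazin-1-yl on a saturated chain carbon, four bonds along the chain from an aromatic nitrogen, gives a 2.8-fold higher number from compound 1 to compound 3 (0.44 log units; beyond the scatter) and so a weaker inhibitor. Among these compounds, this is the first pair here that differs in one place only, and that one place changes in two ways: the group grows from 6 to 9 heavy atoms, and it goes from 1 hydrogen-bond donor to 0. No measurement shown here explains why the number rises.

The compounds shown leave open which part of the change carries the step, the added methyl on the piperazine ring or the longer chain, since both arrive together in compound 3. Also open, from the compounds shown here alone, is how other groups behave at this place, for example a morpholin-4-yl ring or a plain dimethylamino group on the same chain, and whether the number would then move in the same direction.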